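Anilide Swap on a Bis-Nitrobenzylidene Piperidinone Core

The source may report more compounds than this note shows. Statements on the series, on what has been measured and on what is new or still open speak of the compounds shown alone.

Measured so far:
Compound 1, `O=C(/C=C/C(=O)N1C/C(=C\c2ccccc2)C(=O)/C(=C/c2ccccc2)C1)Nc1ccc(Cl)c(Cl)c1`, gives 7500 nM in a functional assay on L1210 cells (Mus musculus) for cytotoxicity; on this read-out higher numbers stand for weaker inhibition and lower numbers for stronger inhibition.
Compound 2, `Cc1cccc(C)c1NC(=O)/C=C/C(=O)N1C/C(=C\c2ccc([N+](=O)[O-])cc2)C(=O)/C(=C/c2ccc([N+](=O)[O-])cc2)C1`, gives 690 nM in this assay.

Of these two numbers, compound 2 has the lower one, and its distance from compound 1 lies beyond the usual scatter of the measurement. The two compounds differ in several places at once, so nothing can be said about which of those changes carries the gap.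

Compound 3, `CC(=O)c1ccc(NC(=O)/C=C/C(=O)N2C/C(=C\c3ccc([N+](=O)[O-])cc3)C(=O)/C(=C/c3ccc([N+](=O)[O-])cc3)C2)cc1`, has not yet been measured. It keeps the shared core of compound 2 and changes only the group on the amide-type nitrogen: 4-acetylphenyl in place of 2,6-dimethylphenyl on an amide-type nitrogen. Going by the values given here, no measured pair in this set isolates such a change, so there is no direct precedent to lean on.

Without such a precedent, the step from compound 2 to compound 3 is expected to be small, a 1.4-fold higher number from compound 2 to compound 3 (0.16 log units; within the scatter), and most likely within the scatter in either direction. On that basis compound 3 is expected to give about 1000 nM in this assay, with a plausible range from 250 nM to 4000 nM.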

Compound 3, half-maximal inhibitory concentration: 1400 nM
Beside the measured number, compound 3's estimate is 1.4-fold (0.15 log units) below it, and the stated range covers the measured number.
By their numbers in this assay, from the lowest: compound 2; then compound 3; then compound 1.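

Going by these compounds alone, this is the first pair here that differs in one place only, so the group on the amide-type nitrogen can now be read on its own. With the shared core kept, in this assay the swap to 4-acetylphenyl gives a 2.0-fold higher number from compound 2 to compound 3 (0.31 log units; beyond the scatter), showing that this position is sensitive to the choice of group, though the modest step lies only just beyond the usual scatter. No available evidence explains the size or direction of this step.

On these data alone, this single swap removes 2,6-dimethylphenyl and brings in 4-acetylphenyl as whole groups, so it remains open whether the step belongs to the loss of the two methyl groups, the arrival of the acetyl group, or both. A plain phenyl group on the same nitrogen would help separate those two contributions, and a 4-methoxyphenyl or 4-carboxyphenyl group would show how much the outcome depends on what the ring carries.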